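Lengthening a Side Chain: From Compound 1 to Compound 4

The source may report more compounds than this note shows. Statements on the series, on what has been measured and on what is new or still open speak of the compounds shown alone.

Of the compounds shown here, three sharing one core have been measured. In a functional assay on HCT-116 cells (Homo sapiens) for inhibition, read by sulforhodamine B assay, with a stated time of 48 h, tested at 50 uM (on this read-out higher numbers stand for more inhibition of growth at the one concentration tested and lower numbers for less inhibition of growth), compound 1 `CCOc1ccc([C@@H]2CC(=O)c3cc(CC=C(C)C)c(OC)cc3O2)cc1` gives 65%. In this assay compound 2 `COc1ccc([C@@H]2C/C(=N/OCc3cn(-c4ccc(O)cc4)nn3)c3cc(CC=C(C)C)c(OC)cc3O2)cc1` gives 65%, which is level with compound 1 at the digits reported, and the two together sit at the bottom of the three numbers. Compound 3 `COc1cc2c(cc1CC=C(C)C)/C(=N/O)C[C@@H](c1ccc(O)cc1)O2` gives 99% in this assay, a result that stands clearly above compound 1 by more than the usual scatter; of the three, only compound 3 stands apart in this way.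

Compound 4 `CCCCOc1ccc([C@@H]2CC(=O)c3cc(CC=C(C)C)c(OC)cc3O2)cc1` has not yet been measured in this assay. It differs from compound 1 in one place: ethyl in place of hydrogen on a saturated chain carbon, two bonds along the chain from an oxygen on an aromatic ring. Among the compounds with values here, no pair of measured compounds that differ in only one place is available, so there is no measured step to lean on. With compound 1 giving 65% as the anchor, the change from compound 1 to compound 4 is expected to produce no step beyond the scatter, estimated as a number 3 percentage points lower from compound 1 to compound 4 (within the scatter). Compound 4 is therefore expected to give about 62%, within a range from 38% to 86%.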

Compound 4, percent growth inhibition at one concentration: 60%
The estimate for compound 4 lay 2 percentage points above the measured number; the measured number falls inside the stated range.
By their numbers in this assay, from the lowest: compounds 4, 1 and 2 (each within the scatter of the next); then compound 3.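

Within the data shown here, replacing ethoxy with butoxy gives the first single-place step in this set: a number 5 percentage points lower from compound 1 to compound 4 (within the scatter) in this assay. At this position, then, adding ethyl to the chain does not move the result outside the usual scatter, so this pair supports neither a gain nor a loss in growth inhibition at the one concentration tested. No supporting measurement is available to explain this result.

The compounds shown leave open whether a longer chain such as hexyloxy, or a chain ending in an amine or a carboxylic acid, would also stay within the scatter of compound 1. They also leave open whether compound 1 and compound 4 would still fall within the scatter of each other at other concentrations.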